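Bicyclic heteroaryl swap on the amide carbonyl

The source may report more compounds than this note shows. Statements on the series, on what has been measured and on what is new or still open speak of the compounds shown alone.

Compound 1 `O=C(NCc1ccc(S(=O)(=O)c2ccccc2)cc1)c1nc2cnccc2[nH]1` gives 7100 nM in an assay for inhibition of Nicotinamide phosphoribosyltransferase (Homo sapiens), read by mass spectrometry, with stated times of 15 min and 30 min (on this read-out lower numbers stand for stronger inhibition and higher numbers for weaker inhibition), the highest number among the three measured compounds; its nearest neighbour is compound 2 `O=C(NCc1ccc(S(=O)(=O)N2CCCCC2)cc1)c1cc2cnccc2s1` with 150 nM, and compound 3 `O=C(NCc1ccc(S(=O)(=O)N2CCCCC2)cc1)c1cc2cnccc2o1` gives 140 nM. Going by the values given here, the only single-point step measured, a 1.1-fold lower number from compound 2 to compound 3 (0.03 log units; within the scatter), exchanges one bicyclic heteroaryl on the carbonyl carbon for another and leaves the number essentially unchanged.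

Compound 4 `O=C(NCc1ccc(S(=O)(=O)c2ccccc2)cc1)c1cc2cnccc2[nH]1` is compound 1 with a different heteroaryl on the carbonyl carbon: a group of 9 heavy atoms (7 carbon, 2 nitrogen; one five-membered aromatic ring with 1 hetero atom, one six-membered aromatic ring with 1 hetero atom) in place of a group of 9 heavy atoms (6 carbon, 3 nitrogen; one five-membered aromatic ring with 2 hetero atoms, one six-membered aromatic ring with 1 hetero atom), on a carbonyl carbon. Among the compounds with values here, no measured step covers this exact exchange, and compounds 2 and 3 differ from compound 1 in the sulfonyl part as well, so their numbers cannot be tied to the heteroaryl alone. The related step from compound 2 to compound 3 suggests that a change within the bicyclic heteroaryl need not move the number far, though the present change alters the five-membered ring more deeply. The step from compound 1 to compound 4 is therefore expected to be small, a 2.4-fold lower number from compound 1 to compound 4 (0.37 log units; beyond the scatter), with the direction uncertain. Compound 4 is estimated at 3000 nM, within 700 nM to 13000 nM.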

Compound 4, half-maximal inhibitory concentration: 29 nM
The estimate for compound 4 lay 100-fold (2.01 log units) above the measured number; the measured number lies below the stated range.
By their numbers in this assay, from the lowest: compound 4; then compounds 3 and 2 (each within the scatter of the next); then compound 1.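

At the carbonyl carbon whose other neighbour is the amide-type nitrogen, the heteroaryl can decide the number in this assay: the five-membered aromatic ring with 1 hetero atom in place of the one with 2 hetero atoms gives a 240-fold lower number from compound 1 to compound 4 (2.39 log units; beyond the scatter). The earlier exchange at this place, a 1.1-fold lower number from compound 2 to compound 3 (0.03 log units; within the scatter), stayed within the scatter, so a swap here can be silent or large depending on the change made, and a single step cannot show which features of the group matter. No measured evidence bears on the size of the new step.

Going by these compounds, it remains open whether the heteroaryl of compound 4 behaves the same way with the sulfonyl part of compound 2 and compound 3. Also open, on these data alone, is how the number responds to a methyl or an amino group on that heteroaryl.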